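From compound 3 to compound 4: one more methoxy group

The compounds below may be only part of what the source reports. "The series", "measured", "known", "first", "only" and "open" are said of these compounds alone.

In an ADME assay on cells (Lymphocyte, Homo sapiens) for cytotoxicity, read by MTT assay, with a stated time of 48 h (on this read-out higher numbers stand for weaker inhibition and lower numbers for stronger inhibition), compound 1 `COC(=O)/C(=C\c1ccc(OC(=O)c2ccccc2)cc1)Sc1ccnc2cc(Cl)ccc12` gives > 100000 nM, which is a limit of the assay and not a number. Compound 2 `COC(=O)/C(=C\c1ccc(OC(=O)c2cc(OC)cc(OC)c2)cc1)Sc1ccnc2cc(Cl)ccc12` gives 84100 nM. Compound 3 `COC(=O)/C(=C\c1ccc(OC(=O)c2cccc(OC)c2OC)cc1)Sc1ccnc2cc(Cl)ccc12` gives 86600 nM, within the scatter of the value for compound 2.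

Compound 4 `COC(=O)/C(=C\c1ccc(OC(=O)c2cc(OC)c(OC)cc2OC)cc1)Sc1ccnc2cc(Cl)ccc12` carries 2,4,5-trimethoxyphenyl in place of 2,3-dimethoxyphenyl on a carbonyl carbon.

Three measured steps changed this same group: an at least 1.1-fold lower number from compound 1 to compound 2 (0.07 log units; that floor lies within the scatter), an at least 1.1-fold lower number from compound 1 to compound 3 (0.06 log units; that floor lies within the scatter) and a 1.0-fold higher number from compound 2 to compound 3 (0.01 log units; within the scatter). None of them goes beyond the scatter, so no change beyond the scatter is expected in this assay. The expected step is a 1.1-fold lower number from compound 3 to compound 4 (0.03 log units; within the scatter). For compound 4, the estimated value is 80000 nM, with an expected range of 40000 nM to 100000 nM.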

Compound 4, half-maximal inhibitory concentration: 52500 nM
The estimate for compound 4 lay 1.5-fold (0.18 log units) above the measured number; low and high end bracket the measured number.
By their numbers in this assay, from the lowest: compounds 4, 2 and 3 (each within the scatter of the next). At a limit, above all of these: compound 1.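

With 2,4,5-trimethoxyphenyl on the carbonyl carbon, this assay gives a 1.6-fold lower number from compound 3 to compound 4 (0.22 log units; within the scatter) and a 1.6-fold lower number from compound 2 to compound 4 (0.20 log units; within the scatter), so one more methoxy group does not move the number beyond the scatter. Against phenyl, the change gives an at least 1.9-fold lower number from compound 1 to compound 4 (0.27 log units; that floor lies within the scatter), which also stays within the scatter. That step is only a floor, because compound 1 stands at a limit and not at a number: the limit of > 100000 nM in this assay, at which 1 of the 4 values shown sits.

On these data alone, it remains open whether a group other than methoxy on this aromatic ring, such as an amine or a carboxylic acid, would move the number beyond the scatter.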